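The compounds below may be only part of what the source reports. "The series", "measured", "known", "first", "only" and "open" are said of these compounds alone.

Compound 2 `CCCOc1cccnc1-c1ccc(C(=O)Nc2ccc(C(C)(C)C)cc2)cc1` is, in a functional assay for antagonist activity at transient receptor potential cation channel subfamily V member 1 (Homo sapiens), read by FLIPR (a lower number here means a stronger inhibitor, a higher number a weaker inhibitor), the weaker of the two measured inhibitors: compound 2 gives 62 nM, the highest of the two numbers available. Compound 1 `Cc1cccnc1-c1ccc(C(=O)Nc2ccc(C(C)(C)C)cc2)cc1` carries a methyl where compound 2 carries a propoxy, and compound 1 gives 11 nM. Among the measured compounds shown here, the single measured step between them is a 5.6-fold higher number from compound 1 to compound 2 (0.75 log units; beyond the scatter), the only change so far recorded at this position on the ring.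

Compound 3 `CC(C)(C)c1ccc(NC(=O)c2ccc(-c3ncccc3C#N)cc2)cc1` has not yet been measured. It differs from compound 2 in one place: cyano in place of propoxy on an aromatic carbon. The group that leaves is the propoxy with its 4 heavy atoms, and the group that enters is the cyano with its 2 heavy atoms, on an aromatic carbon of the six-membered aromatic ring with 1 nitrogen, ortho to a large group.

For the measured compounds named here, the step from compound 1 to compound 2 is the only measured step that bears on this change, and it was modest and beyond the scatter. Taking the propoxy away again is therefore expected to lower the number by a modest amount, a 3.1-fold lower number from compound 2 to compound 3 (0.49 log units; beyond the scatter). Compound 3 is estimated at 20 nM, with a range from 6 nM to 70 nM.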

Compound 3, half-maximal inhibitory concentration: 30 nM
Beside the measured number, compound 3's estimate is 1.5-fold (0.18 log units) below it; measured number inside the range.
By their numbers in this assay, from the lowest: compound 1; then compound 3; then compound 2.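

In this assay, this position now carries three different groups, and a second kind of replacement can be compared with the first. Cyano recovers part of what propoxy gave up (a change of a 2.1-fold lower number from compound 2 to compound 3 (0.32 log units; beyond the scatter)), yet it does not match methyl (a change of a 2.7-fold higher number from compound 1 to compound 3 (0.44 log units; beyond the scatter)), so compound 3 falls in the middle of the three and the position shows a graded order rather than a simple split into groups that work and groups that fail. No measurement here accounts for this order, and the numbers alone give no reason why the three groups rank as they do.

The compounds shown leave open whether the order follows the size of the group, since propoxy, with its 4 heavy atoms, and cyano, with its 2, also differ in other ways than atom count. A methoxy or a butoxy would test how the number changes with chain length while the oxygen stays in place, and an amine or a carboxylic acid would show how far this position accepts a quite different kind of group.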